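Swapping trifluoromethyl for methylsulfonyl in compound 3

The compounds below may be only part of what the source reports. "The series", "measured", "known", "first", "only" and "open" are said of these compounds alone.

In an ADME assay on PBMC cells (Homo sapiens) for cytotoxicity (on this read-out higher numbers stand for lower toxicity in this test and lower numbers for higher toxicity in this test), compound 3 (`CC(CCNC(=O)c1c(Cl)cncc1Cl)N1CCC(C(Oc2cccc(Cl)n2)c2ccc(C(F)(F)F)cc2)CC1`) gives > 32500 nM as its reading, which is a limit of the assay and not a number. Its standing is therefore known only as a limit (the limit of > 32500 nM in this assay, at which 1 of the 3 values shown sits). Compound 4 (`CC(CCNC(=O)c1c(Cl)cncc1Cl)N1CCC(C(Oc2cccc(Cl)n2)c2ccc(S(C)(=O)=O)cc2)CC1`) carries methylsulfonyl in place of trifluoromethyl on an aromatic carbon.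

Among the measured compounds shown here, no measured compound carries methylsulfonyl, so two steps offer only indirect guidance. Compound 1 (`CC(CCNC(=O)c1c(Cl)cncc1Cl)N1CCC(C(Oc2cccc(Cl)n2)c2ccc(OC(F)(F)F)cc2)CC1`) gives 6000 nM and differs from compound 3 in the group at the same place, with trifluoromethoxy there instead of trifluoromethyl (an at least 5.4-fold higher number from compound 1 to compound 3 (0.73 log units; beyond the scatter)). That step shows that a change at this place can matter. Compound 2 (`CC(CCNC(=O)c1c(Cl)cncc1Cl)N1CCC(C(Oc2cccc(C(=O)O)n2)c2ccc(C(F)(F)F)cc2)CC1`) gives 28700 nM and differs elsewhere, with carboxy in place of chloro (an at least 1.1-fold higher number from compound 2 to compound 3 (0.05 log units; that floor lies within the scatter)).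

For the measured compounds named here, a lower number than for compound 3 is possible, but a step as large as the one from compound 1 is not assumed. The expected change is small and lies within the scatter (an at least 1.0-fold lower number from compound 3 to compound 4 (0.03 log units; that floor lies within the scatter)) in the direction of a lower number. The estimated value for compound 4 is 30000 nM with an expected range from 10000 nM to 65000 nM in this assay.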

Compound 4, half-maximal cytotoxic concentration: > 29500 nM
Compound 4 was reported as a limit; the forecaster's own chance of this, stated with the estimate: 50%; the middle value lies beyond the limit too.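

In this assay, the reading for compound 4 is a limit and not a number: the limit of > 29500 nM in this assay, at which 1 of the 4 values shown sits. The reading for compound 3 is likewise a limit: the limit of > 32500 nM in this assay, at which 1 of the 4 values shown sits. The step between these two compounds cannot be read, but methylsulfonyl, like trifluoromethyl, stands clearly apart from trifluoromethoxy at this place on the six-membered aromatic ring, with an at least 4.9-fold higher number from compound 1 to compound 4 (0.69 log units; beyond the scatter), so the lower number seen with trifluoromethoxy does not extend to this replacement.

From the compounds shown here alone, whether methylsulfonyl and trifluoromethyl differ at all in this test stays open, and only readings that end below the limits could settle it. Also open, going by these compounds, is how a different group at this place, such as a primary amine or a nitrile, would read.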